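Swapping the aryl acyl group for a short chain

The source may report more compounds than this note shows. Statements on the series, on what has been measured and on what is new or still open speak of the compounds shown alone.

Of the compounds shown here, three have been measured in a functional assay on NUGC-3 cells (Homo sapiens) for cytotoxicity, read by sulforhodamine B assay, with a stated time of 72 h; on this read-out lower numbers stand for stronger inhibition of growth and higher numbers for weaker inhibition of growth. Compound 1 `O=C(Nc1ccccc1C(F)(F)F)C1CCc2ccccc2N1C(=O)c1ccccc1` gives 8120 nM. Compound 2 `O=C(Nc1ccccc1)C1CCc2ccccc2N1`, which lacks any group on the ring nitrogen, gives 59000 nM. Compound 3 `O=C(Nc1cc(C(F)(F)F)cc(C(F)(F)F)c1)C1CCc2ccccc2N1C(=O)c1ccccc1Cl` gives 1930 nM, the lowest of the three numbers, and both of its gaps to the other two lie beyond the scatter of this kind of measurement.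

Compound 4 `CCC(=O)N1c2ccccc2CCC1C(=O)Nc1cc(C(F)(F)F)cc(C(F)(F)F)c1` has not yet been tested in this assay. Its difference from compound 3 is a single one: ethyl in place of 2-chlorophenyl on a carbonyl carbon. Among the compounds with values here, no measured pair of compounds shows this same change, so there is no step to lean on; the only guide is that compound 2, carrying nothing at all on the ring nitrogen, is the weakest of the three, while compound 3, carrying the 2-chlorophenyl group, is the strongest. A move from that group to a small ethyl is therefore expected to lose some activity, with the step from compound 3 to compound 4 estimated at a 3.1-fold higher number from compound 3 to compound 4 (0.49 log units; beyond the scatter). Compound 4 is accordingly expected to give about 6000 nM, within a range of 2000 nM to 20000 nM.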

Compound 4, concentration for 50% growth inhibition: 7220 nM
Beside the measured number, compound 4's estimate is 1.2-fold (0.08 log units) below it; low and high end bracket the measured number.
By their numbers in this assay, from the lowest: compound 3; then compounds 4 and 1 (each within the scatter of the next); then compound 2.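

In this assay, within the data shown here, this position can now be read directly for the first time: ethyl in place of 2-chlorophenyl on a carbonyl carbon gives a 3.7-fold higher number from compound 3 to compound 4 (0.57 log units; beyond the scatter) with the rest of the molecule unchanged, a modest step that lies beyond the scatter. The group on this carbonyl therefore affects the read-out, and the larger aromatic group gives the lower number of this pair, although compound 4, with no ring at this place, still gives a measured value of 7220 nM. Nothing available here accounts for the size of this step.

From the compounds shown here alone, it remains open whether the ring or its chlorine matters more, and how a plain phenyl, a longer chain such as butyl, or a chain carrying an amine would read here. Going by these compounds, whether the step keeps its size with the other amide side of compound 1 is also open.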